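Methyl on the anilide ring: a small change tested

The compounds below may be only part of what the source reports. "The series", "measured", "known", "first", "only" and "open" are said of these compounds alone.

Measured so far:
Compound 1 `CN1C[C@@H](COc2ccc(C(=O)Nc3cccc(CC(=O)O)c3)c(Cl)c2)Oc2ccccc21` — 20 nM
Compound 2 `Cc1cc(OC[C@@H]2CN(C)c3ccccc3O2)ccc1C(=O)Nc1cccc(CC(=O)O)c1C` — 28 nM
Compound 3 `Cc1cc(OC[C@@H]2CN(C)c3ccccc3O2)ccc1C(=O)Nc1ccc(F)c(CC(=O)O)c1` — 1.2 nM

In a functional assay on CHO cells for antagonist activity at prostaglandin D2 receptor (Mus musculus), read by cAMP accumulation (on this read-out higher numbers stand for weaker inhibition and lower numbers for stronger inhibition), compound 1 gives the second highest of the three numbers; compound 2 lies within the scatter of it, while compound 3 sits well below it. Compound 4 `Cc1ccc(CC(=O)O)cc1NC(=O)c1ccc(OC[C@@H]2CN(C)c3ccccc3O2)cc1Cl` differs from compound 1 by methyl in place of hydrogen on an aromatic carbon, placed ortho to a large group and para to a carboxymethyl group. Among the compounds with values here, the only measured step, a 23-fold lower number from compound 2 to compound 3 (1.37 log units; beyond the scatter), moves a methyl and adds a fluorine at once, so it speaks only loosely to a lone methyl. A step of no change at the digits printed from compound 1 to compound 4 (within the scatter) is therefore expected, meaning compound 4 is estimated at 20 nM, between 6 nM and 60 nM.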

Compound 4, half-maximal inhibitory concentration: 6 nM
Compound 4: middle estimate off by 3.3-fold (0.52 log units), on the high side; measured number inside the range.
By their numbers in this assay, from the lowest: compound 3; then compound 4; then compounds 1 and 2 (each within the scatter of the next).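

On its own, a methyl ortho to a large group and para to a carboxymethyl group gives a 3.3-fold lower number from compound 1 to compound 4 (0.52 log units; beyond the scatter) in this assay. Unlike a 23-fold lower number from compound 2 to compound 3 (1.37 log units; beyond the scatter), which makes more than one change at once, this step isolates a single methyl in place of hydrogen, so its effect on the number can be read directly. Nothing available here says why the number falls. From the compounds shown here alone, whether an ethyl or a methoxy group on the same carbon would give a similar step remains open. So does whether the methyl would have the same effect with a methyl rather than the chlorine of compound 4 on the other aromatic ring.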